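The source may hold more compounds than are shown below. What is called first, only, known or untested is meant among the compounds shown, and "the series" means these compounds.

In a physicochemical assay for permeability, using PAMPA (on this read-out lower numbers stand for lower permeability and higher numbers for higher permeability), compound 3 `O=C(O)CCn1c(=O)oc2cc(OCC3CC3)c(Cl)cc21` gives 19 nm/s and compound 2 `O=C(O)CCn1c(=O)oc2cc(OCc3ccccn3)c(Cl)cc21` gives 11 nm/s. The gap between them, a 1.7-fold higher number from compound 2 to compound 3 (0.24 log units; within the scatter), leaves the two level. Compound 1 `C[C@@H](Oc1cc2oc(=O)n(CCC(=O)O)c2cc1Cl)c1cccnn1` reports only a limit, < 3 nm/s. Compound 4 `C[C@@H](Oc1cc2oc(=O)n(CCC(=O)O)c2cc1Cl)c1ncccn1` differs from compound 3 on an oxygen on an aromatic ring: a group of 8 heavy atoms (6 carbon, 2 nitrogen; one six-membered aromatic ring with 2 hetero atoms) in place of a group of 4 heavy atoms (4 carbon; one three-membered non-aromatic ring of carbon only), on an oxygen on an aromatic ring. The closest guide is an at least 6.3-fold higher number from compound 1 to compound 3 (0.80 log units; beyond the scatter), which exchanges groups of the same counts in the opposite direction, while an at least 3.6-fold higher number from compound 1 to compound 2 (0.56 log units; beyond the scatter) also favours the group without the second ring nitrogen. Both lie beyond the scatter, so a fall of similar size is expected in this assay. The expected change is a 4.8-fold lower number from compound 3 to compound 4 (0.68 log units; beyond the scatter). For compound 4 the estimated value is 4 nm/s, with an expected range of 2 nm/s to 10 nm/s.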

Compound 4, apparent permeability: < 3 nm/s
Compound 4: no number, only a limit; the forecaster's own chance of this, stated with the estimate: 40%; middle value at least 1.3-fold (0.12 log units) away from the limit.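

In this assay, placing the group of compound 4 on the oxygen in place of cyclopropylmethyl gives an at least 6.3-fold lower number from compound 3 to compound 4 (0.80 log units; beyond the scatter), and the comparison with the pyridin-2-yl group gives an at least 3.6-fold lower number from compound 2 to compound 4 (0.56 log units; beyond the scatter). Among the compounds shown here, the fall earlier seen only with pyridazin-3-yl in compound 1 thus also appears with pyrimidin-2-yl. Compound 1 and compound 4 cannot be ordered, and their step cannot be read, because both sit at a limit: the limit of < 3 nm/s in this assay, at which 2 of the 4 values shown sit.

The compounds shown leave open whether the fall goes with the two ring nitrogens or with the defined stereocentre, which compound 2 and compound 3 lack. As far as these compounds go, how a phenyl ring would read at this place also remains open.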